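From Amide to Urea at the Carbonyl Carbon

The source may report more compounds than this note shows. Statements on the series, on what has been measured and on what is new or still open speak of the compounds shown alone.

Two compounds sharing one core were measured in a functional assay on SK-OV-3 cells (Homo sapiens) for inhibition, read by sulforhodamine B assay, with a stated time of 48 h; a higher number here means a weaker inhibitor of growth, a lower number a stronger inhibitor of growth. Compound 1 `COc1cc(-c2nn(-c3cccc(NC(=O)c4ccc(Cl)c(C(F)(F)F)c4)c3)cc2-c2ccncc2)ccc1Cl` gives 9290 nM, the highest of the two numbers. For the measured compounds named here, compound 2 `O=C(Nc1cccc(-n2cc(-c3ccncc3)c(-c3ccc(Cl)c(O)c3)n2)c1)Nc1cc(C(F)(F)F)cc(C(F)(F)F)c1` gives 1350 nM, a gap beyond the usual scatter; compound 2 differs from compound 1 in more than one place, so no single step is known. Compound 3 `COc1cc(-c2nn(-c3cccc(NC(=O)Nc4ccc(Cl)c(C(F)(F)F)c4)c3)cc2-c2ccncc2)ccc1Cl` has not yet been measured. It differs from compound 1 in one place: (4-chloro-3-(trifluoromethyl)phenyl)amino in place of 4-chloro-3-(trifluoromethyl)phenyl on a carbonyl carbon. The urea of compound 2 offers the only hint, pointing to a lower number. The expected step is a 2.7-fold lower number from compound 1 to compound 3 (0.42 log units; beyond the scatter), possibly still within the scatter. Compound 3 is estimated at 3500 nM, within 1200 nM to 10000 nM.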

Compound 3, concentration for 50% growth inhibition: 1450 nM
The estimate for compound 3 lay 2.4-fold (0.38 log units) above the measured number; the range from low to high includes it.
By their numbers in this assay, from the lowest: compounds 2 and 3 (each within the scatter of the next); then compound 1.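

Replacing 4-chloro-3-(trifluoromethyl)phenyl with (4-chloro-3-(trifluoromethyl)phenyl)amino on a carbonyl carbon turns the amide into a urea and gives a 6.4-fold lower number from compound 1 to compound 3 (0.81 log units; beyond the scatter) in this assay. The urea's link to a lower number now rests on a single change, not on a comparison between compounds that differ in several places. The change adds one nitrogen and one hydrogen-bond donor, but nothing measured here explains the shift.

On these data alone, whether that nitrogen itself matters remains open. A methylene group or an oxygen atom in its place could give a similar or a different number.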